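Adding a Hydroxy Group to a Weakly Antiproliferative Series

The source may hold more compounds than are shown below. What is called first, only, known or untested is meant among the compounds shown, and "the series" means these compounds.

Measured compounds:
compound 1, `C/C(=N\NC(=S)N1CCNCC1)c1ccc(O)cc1`, 60000 nM
compound 2, `S=C(N/N=C/c1ccccc1)N1CCNCC1`, 63000 nM
compound 3, `S=C(NN=C(c1ccccc1)c1ccccc1)N1CCNCC1`, "not determined" (no result reported)

Of the compounds shown here, three of the shared core have been tested in a functional assay on HL-60 cells (Homo sapiens) for antiproliferative activity, with a stated time of 48 h; a higher number here means a weaker inhibitor, a lower number a stronger inhibitor. Compound 1 gives 60000 nM. Compound 2 gives 63000 nM. For compound 3 the entry in this assay reads "not determined" (no result reported). Going by the values given here, on the numbers at hand compound 2 and compound 1 sit within the scatter of each other, so neither can be called the stronger or weaker inhibitor; both are weak, and no pair among the measured compounds differs in only one place, so no single-change step can be read off.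

The next compound is compound 4, `Oc1ccc(/C=N/NC(=S)N2CCNCC2)cc1`. It arises from compound 2 by hydroxy in place of hydrogen on an aromatic carbon.

Compound 1 already carries a hydroxy group on the same kind of aromatic carbon and in this assay gives 60000 nM, a number close to that of compound 2. On that basis the step from compound 2 to compound 4 is expected to stay within the scatter, with no clear direction, as an estimated 1.1-fold lower number from compound 2 to compound 4 (0.06 log units; within the scatter). For compound 4 the expected result in this assay is 55000 nM, with a range from 25000 nM to 120000 nM.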

Compound 4, half-maximal inhibitory concentration: 50000 nM
Estimate against measurement, compound 4: 1.1-fold (0.04 log units) above, within the range that was stated.
By their numbers in this assay, from the lowest: compounds 4, 1 and 2 (each within the scatter of the next).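

In this assay the series now has its first readable single-change step: hydroxy in place of hydrogen on an aromatic carbon, para to a large group, gives a 1.3-fold lower number from compound 2 to compound 4 (0.10 log units; within the scatter) and so lies within the scatter. This position therefore tolerates the added hydroxy group, with its one hydrogen-bond donor and one acceptor, but the change shows no measurable effect in either direction, and compound 4 at 50000 nM is still a weak inhibitor. No supporting measurement is available to explain this flat result.

Going by these compounds, whether any substituent at this position can move the number beyond the scatter remains open: a methoxy group, an amine, a carboxylic acid or a fluorine atom in place of the hydroxy group would test this, since a single polar substituent is all the step covers. Compound 3 has no number in this assay and adds nothing to the comparison, so it is also unknown whether changes elsewhere on the shared core, such as a longer chain on the piperazine nitrogen, do more than this one.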